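Dichlorophenyl Replaces Methoxyphenyl on a Triazole Nitrogen

This account rests on a few compounds, and the source may have more. Where it says the series, first, only, none or still open, it means among the compounds named here.

Measured compounds:
compound 1, `COc1ccc(-n2nncc2CN2C(=O)C3(C(C#N)=C(N)Oc4c3c3nc5ccccc5nc3c3ccccc43)c3ccccc32)cc1`: in an ADME assay on HUVEC cells (Homo sapiens) for antiproliferative activity, read by MTT assay, with a stated time of 48 h (on this read-out lower numbers stand for stronger inhibition and higher numbers for weaker inhibition), compound 1 gives > 50000 nM, which is a limit of the assay.
compound 2, `CCOc1ccccc1-n1nncc1CN1C(=O)C2(C(C#N)=C(N)Oc3c2c2nc4ccccc4nc2c2ccccc32)c2ccccc21`: in this assay compound 2 gives > 50000 nM, which is likewise a limit of the assay.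

On the numbers shown, compound 1 stands only at a limit, and the one further value shown is a limit too. Among the compounds with values here, the single measured step, a step that the two limits leave unreadable from compound 1 to compound 2, therefore cannot be read in either size or direction, both of its values resting at the limit of > 50000 nM in this assay, at which 2 of the 2 values shown sit.

Compound 3, `N#CC1=C(N)Oc2c(c3nc4ccccc4nc3c3ccccc23)C12C(=O)N(Cc1cnnn1-c1ccc(Cl)c(Cl)c1)c1ccccc12`, is the compound not yet measured. It differs from compound 1 by 3,4-dichlorophenyl in place of 4-methoxyphenyl on an aromatic nitrogen. Within the data shown here, the only step that bears on this change is a step that the two limits leave unreadable from compound 1 to compound 2, which also exchanges one aryl group on the same aromatic nitrogen and which showed nothing readable. Among the measured compounds shown here, from the measured steps no size of step in this assay can be expected, in either direction, beyond the scatter. The expected step, a number no higher from compound 1 to compound 3 (the limit leaves the size open), is therefore taken to be none beyond the scatter. Compound 3 is estimated at 50000 nM, with a range from 20000 nM to 100000 nM, and most likely the assay will again report only a limit.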

Compound 3, half-maximal inhibitory concentration: > 50000 nM
Compound 3 was reported as a limit; the forecaster's own chance of this, stated with the estimate: 80%; the middle value lies on the limit itself.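

In this assay compound 3 gives > 50000 nM, which is a limit of the assay. The steps among compound 1, compound 2 and compound 3 therefore cannot be read, as all three rest at the same limit: the limit of > 50000 nM in this assay, at which 3 of the 3 values shown sit. The compounds shown leave open whether any aryl group on this aromatic nitrogen would give a measurable value in this assay.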